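Removing the sulfamoyl group: what to expect for compound 3

The compounds below may be only part of what the source reports. "The series", "measured", "known", "first", "only" and "open" are said of these compounds alone.

Measured so far in a functional assay on WiDr cells (Homo sapiens) for inhibition; on this read-out lower numbers stand for stronger inhibition and higher numbers for weaker inhibition:
compound 1, `N#CC1CN1C(=O)Nc1ccc(S(N)(=O)=O)cc1`, gives > 38000 nM.
compound 2, `CC(C)(C)NC(=O)N1CC1C#N`, gives 180000 nM.

For compound 1 the value > 38000 nM is a limit of the assay, not a measured number. Compound 1 therefore stands at the limit of > 38000 nM in this assay, at which 1 of the 2 values shown sits, and nothing more precise is known of it. For the measured compounds named here, compound 2, with 180000 nM in this assay, is a weak inhibitor and shares no single point of difference with compound 1, so no step between the two can be read off; their values show only that both sit at the weak end of the scale.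

Compound 3, `N#CC1CN1C(=O)Nc1ccccc1`, has not been measured. It differs from compound 1 in one place: hydrogen in place of sulfamoyl on an aromatic carbon. Since compound 1 is known only as a limit, any step from it is itself uncertain. In this assay the step from compound 1 to compound 3 is expected to be a step that the limit leaves unreadable from compound 1 to compound 3, that is, no change beyond the usual scatter. Compound 3 is accordingly expected to give about 100000 nM, most likely between 30000 nM and 400000 nM.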

Compound 3, half-maximal inhibitory concentration: 5000 nM
Compound 3: the middle estimate sits 20-fold (1.30 log units) above what was measured, outside the stated range (below it).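

In this assay, hydrogen in place of sulfamoyl on the aromatic carbon gives an at least 7.6-fold lower number from compound 1 to compound 3 (0.88 log units; beyond the scatter). This shows that the place para to a group of 8 heavy atoms matters for this read-out: what sits there can move the number beyond the usual scatter, here towards stronger inhibition, which no earlier comparison could reveal. The true size of the step stays unknown, and it can be stated only as a minimum, because the value of compound 1 is a limit and not a number: the limit of > 38000 nM in this assay, at which 1 of the 3 values shown sits.

Only sulfamoyl and hydrogen are shown at this place, so it remains open whether sulfamoyl as such weakens inhibition or whether any group there would do the same, as a methyl group, a fluorine atom, an amine or a carboxylic acid might show. From the compounds shown here alone, it is also open which feature of the departing group counts, whether its 4 heavy atoms or its hydrogen-bond donor and acceptors, and how the other carbons of the aromatic ring respond to the same change.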